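This account rests on a few compounds, and the source may have more. Where it says the series, first, only, none or still open, it means among the compounds named here.

Measured in a functional assay on L5178Y cells (Mus musculus) for inhibition, read by MTT assay, with a stated time of 24 h; a lower number here means a stronger inhibitor, a higher number a weaker inhibitor:
- Compound 1, `N/N=C1\C[C@@H](c2ccc(O)cc2)Oc2cc(O)cc(O)c21`: >= 11300 nM
- Compound 2, `O=C(N/N=C1\C[C@@H](c2ccc(O)cc2)Oc2cc(O)cc(O)c21)c1cccs1`: >= 11300 nM

Both entries are limits of the assay, not exact numbers, and the record shows (the limit of >= 11300 nM in this assay, at which 2 of the 2 values shown sit). Compound 2 stands at >= 11300 nM, which is a limit. Compound 3, `CN(C)C(=S)N/N=C1\C[C@@H](c2ccc(O)cc2)Oc2cc(O)cc(O)c21`, differs from compound 2 on an amine nitrogen: a group of 5 heavy atoms (3 carbon, 1 nitrogen, 1 sulfur; no ring) in place of a group of 7 heavy atoms (5 carbon, 1 oxygen, 1 sulfur; one five-membered aromatic ring with 1 hetero atom), on an amine nitrogen. Among the measured compounds shown here, the only measured step bearing on this change is a step that the two limits leave unreadable from compound 1 to compound 2, so it offers no size to carry over. No step beyond the scatter can therefore be predicted with confidence in this assay. The expected change is a step that the limit leaves unreadable from compound 2 to compound 3. For compound 3, the estimated value is 12000 nM, within an expected range of 4000 nM to 25000 nM.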

Compound 3, half-maximal inhibitory concentration: >= 11300 nM
Compound 3 ended at the assay's limit (the forecaster's own chance of this, stated with the estimate: 60%); the middle value lies beyond the limit too.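

No step can be read among compound 1, compound 2 and compound 3, because all three stop at one limit rather than at exact numbers: the limit of >= 11300 nM in this assay, at which 3 of the 3 values shown sit.

The compounds shown leave open whether changing the group on the amine nitrogen alters inhibition in this assay at all.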